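Changing the Aryl Arm of Compound 1

The compounds below may be only part of what the source reports. "The series", "measured", "known", "first", "only" and "open" are said of these compounds alone.

Measured compounds:
compound 1 `CCOC(=O)C1=C(Nc2ccccc2)S/C(=C\c2ccc(C(=O)O)cc2)C1=O` — 16.8%
compound 2 `CCOC(=O)C1=C(Nc2ccc(C)cc2)S/C(=C\c2ccc[nH]2)C1=O` — < 10%, a limit of the assay rather than a number

For the measured compounds named here, in a functional assay on JAR cells (Homo sapiens) for inhibition, read by MTT assay, with a stated time of 72 h, tested at 10 uM (on this read-out higher numbers stand for more inhibition at the one concentration tested (going by the name of the read-out) and lower numbers for less inhibition), compound 1 gives 16.8%, and this is the only plain number among the two measured compounds. Compound 2 is reported only as < 10%, which is a limit of the assay and not a measured number; this is the limit of < 10% in this assay, at which 1 of the 2 values shown sits. Going by the values given here, no step between two measured compounds that differ in a single place is available here, so the size of the change cannot be calibrated from them.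

Compound 3 `CCOC(=O)C1=C(Nc2ccccc2)S/C(=C\c2cc3ccncc3[nH]2)C1=O` differs from compound 1 as follows: a group of 9 heavy atoms (7 carbon, 2 nitrogen; one five-membered aromatic ring with 1 hetero atom, one six-membered aromatic ring with 1 hetero atom) in place of a group of 9 heavy atoms (7 carbon, 2 oxygen; one six-membered aromatic ring of carbon only), on a double-bonded chain carbon bound to a double-bonded ring carbon. With nothing to anchor the change, the expected step of a number 1.8 percentage points lower from compound 1 to compound 3 (within the scatter) is taken to lie within the usual scatter of this assay, in no firm direction. Compound 3 is therefore estimated at 15%, with a range from 0% to 35%, and a real chance that only a limit is reported.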

Compound 3, a percentage reported as inhibition, at one concentration (the size of the read-out at that concentration, not a potency): 26.3%
Estimate against measurement, compound 3: 11.3 percentage points below; the range from low to high includes it.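

For the compounds shown here, the step at this place, on a double-bonded chain carbon bound to a double-bonded ring carbon, is the first that can be read between two measured compounds: a number 9.5 percentage points higher from compound 1 to compound 3 (within the scatter). In this assay, the 4-carboxyphenyl group can therefore give way to a group with one five-membered and one six-membered aromatic ring, each with a hetero atom, without a change beyond the scatter, so the carboxylic acid is not needed for a read-out of this size on the core of compound 1. Going by these compounds alone, compound 2 remains the only compound at a limit of the assay, which is not a number: the limit of < 10% in this assay, at which 1 of the 3 values shown sits.

The compounds shown leave open how a plain phenyl, or a phenyl carrying an amine, would read at this place. They also leave open whether the aryl arm matters more on a core with a longer chain in place of the ethyl ester.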